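Swapping dimethylamino for 2-oxopyrrolidin-1-yl on the shared core

The source may hold more compounds than are shown below. What is called first, only, known or untested is meant among the compounds shown, and "the series" means these compounds.

Measured in a toxicity assay on THP-1 cells (Homo sapiens) for cytotoxicity; a lower number here means that less compound is needed, a higher number that more compound is needed for the effect:
Compound 1 `CNc1ccnc2c(O)c(-c3nc(C)n[nH]3)ncc12`: > 50100 nM (a limit)
Compound 2 `Cc1n[nH]c(-c2ncc3c(N(C)C)ccnc3c2O)n1`: > 50100 nM (a limit)

In this assay, compound 2 gives only a limit, > 50100 nM. The two measured compounds share one result: the limit of > 50100 nM in this assay, at which 2 of the 2 values shown sit.

Compound 3 `Cc1n[nH]c(-c2ncc3c(N4CCCC4=O)ccnc3c2O)n1` carries 2-oxopyrrolidin-1-yl in place of dimethylamino on an aromatic carbon, opposite the ring nitrogen: 2-oxopyrrolidin-1-yl in place of dimethylamino on an aromatic carbon.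

For the measured compounds named here, the only measured step is a step that the two limits leave unreadable from compound 1 to compound 2, with methyl in place of hydrogen on a nitrogen on an aromatic ring. It is a different change and offers no size to carry over. No step beyond the usual scatter, in either direction, is therefore expected in this assay, and another limit is the likeliest result. The expected size is a number no higher from compound 2 to compound 3 (the limit leaves the size open). Compound 3 is estimated at 50100 nM, with an expected range of 20000 nM to 100000 nM.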

Compound 3, half-maximal effective concentration: > 50100 nM
Compound 3 ended at the assay's limit (the forecaster's own chance of this, stated with the estimate: 85%); the middle value sits exactly at the limit.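

In this assay compound 3, like compound 1 and compound 2, gives only a limit, so no step between any of them can be read: the limit of > 50100 nM in this assay, at which 3 of the 3 values shown sit.

Left open is how much of each compound the effect requires, and whether 2-oxopyrrolidin-1-yl in place of dimethylamino changes that amount at all.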